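Branching at the aromatic nitrogen in a steroid 5-alpha-reductase series

The compounds below may be only part of what the source reports. "The series", "measured", "known", "first", "only" and "open" are said of these compounds alone.

Compound 1 `CCCCCCCn1ccc2cc(/C(C)=C/C(=O)Nc3ccccc3OCCCC(=O)O)ccc21` carries a heptyl group on an aromatic nitrogen of the shared core. Among the compounds with values here, in an assay on Prostate gland for inhibition of steroid 5-alpha-reductase (Rattus norvegicus) (on this read-out lower numbers stand for stronger inhibition and higher numbers for weaker inhibition), compound 1 gives 120 nM, the highest of the three numbers measured so far. Compound 2 `CCCCC(CCCC)n1ccc2cc(/C(C)=C/C(=O)Nc3ccccc3OCCCC(=O)O)ccc21` gives 21 nM, and compound 3 `C/C(=C\C(=O)Nc1ccccc1OCCCC(=O)O)c1ccc2c(ccn2C(C)c2ccccc2)c1` gives 19 nM; the two replacements of heptyl, a 5.7-fold lower number from compound 1 to compound 2 (0.76 log units; beyond the scatter) and a 6.3-fold lower number from compound 1 to compound 3 (0.80 log units; beyond the scatter), were each modest steps beyond the scatter, while a 1.1-fold lower number from compound 2 to compound 3 (0.04 log units; within the scatter) lay within the scatter.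

Compound 4 `CCCCCC(c1ccccc1)n1ccc2cc(/C(C)=C/C(=O)Nc3ccccc3OCCCC(=O)O)ccc21` differs from compound 1 by 1-phenylhexyl in place of heptyl on an aromatic nitrogen. This change combines the branching seen in 1-butylpentyl with the aromatic ring seen in 1-phenylethyl, and both of those earlier steps bear on it. The account therefore expects a modest lowering of the number for compound 4, of about the same size as those steps, as expressed by a 5.5-fold lower number from compound 1 to compound 4 (0.74 log units; beyond the scatter). The estimate for compound 4 is 22 nM, with a range from 8 nM to 60 nM.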

Compound 4, half-maximal inhibitory concentration: 25 nM
The estimate for compound 4 lay 1.1-fold (0.06 log units) below the measured number; low and high end bracket the measured number.
By their numbers in this assay, from the lowest: compounds 3, 2 and 4 (each within the scatter of the next); then compound 1.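

In this assay, the lower number seen with either branching or an aromatic ring on the aromatic nitrogen also holds when both sit on one carbon, as 1-phenylhexyl (a 4.8-fold lower number from compound 1 to compound 4 (0.68 log units; beyond the scatter)), a modest step beyond the scatter. Neither the butyl in place of hydrogen on the saturated chain carbon (a 1.3-fold higher number from compound 3 to compound 4 (0.12 log units; within the scatter)) nor the exchange of 1-butylpentyl for 1-phenylhexyl (a 1.2-fold higher number from compound 2 to compound 4 (0.08 log units; within the scatter)) leaves the scatter, so among compounds 2, 3 and 4 the larger group gives no readable difference and the two features together show no added gain. Nothing available here explains this result.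

The compounds shown leave open whether a benzyl group, with the ring but no branch, would match these branched groups. They also leave open how an amine or a carboxylic acid on the group at this nitrogen would read.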